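Methoxy in Place of Bromo on Two Related Cores

The compounds below may be only part of what the source reports. "The series", "measured", "known", "first", "only" and "open" are said of these compounds alone.

Measured compounds:
compound 1, `CCOC(=O)Cc1nc(N)n(C(=O)c2ccc(Br)cc2)n1`: 43%
compound 2, `CCOC(=O)Cc1nc(N)n(C(=O)c2ccc(OC)cc2)n1`: 41.5%
compound 3, `CCOC(=O)Cc1n[nH]c(NC(=O)c2ccc(Br)cc2)n1`: 40.4%

In a functional assay on the whole organism (strain albino) for inhibition, with Rattus norvegicus as the target, read by paw edema, with stated times of 30 min and 2 h, at a dose of 5 mg/kg by the oral route (a lower number here means less inhibition, a higher number more inhibition at the dose given (going by the name of the read-out)), compound 1 gives 43%. Compound 2 differs from it in one place, (methoxy in place of bromo on an aromatic carbon), and in this assay compound 2 gives 41.5%. The step of a number 1.5 percentage points lower from compound 1 to compound 2 (within the scatter) is within the scatter, so the two values cannot be told apart.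

Compound 3 has the same atoms as compound 1 joined differently; the difference between the two cores is not broken down here. In this assay compound 3 gives 40.4%, which sits within the scatter of both compound 1 and compound 2.

Compound 4, `CCOC(=O)Cc1n[nH]c(NC(=O)c2ccc(OC)cc2)n1`, has not yet been measured. It differs from compound 3 by methoxy in place of bromo on an aromatic carbon, the same change that turns compound 1 into compound 2, at a place described in the same words. That change was made once among the measured compounds and left the read-out essentially unchanged. Because the step of a number 1.5 percentage points lower from compound 1 to compound 2 (within the scatter) lay within the scatter, a similarly small step is expected on the core of compound 3; the expected step is a number 1.4 percentage points lower from compound 3 to compound 4 (within the scatter). The estimate for compound 4 in this assay is 39%, expected to fall between 29% and 49%. This rests on a single precedent, so the range is kept wide.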

Compound 4, a percentage reported as inhibition, in the whole organism at one dose (the size of the read-out at that dose, not a potency): 38.2%
Beside the measured number, compound 4's estimate is 0.8 percentage points above it; the range from low to high includes it.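

In this assay, methoxy in place of bromo on the core of compound 3 gives a number 2.2 percentage points lower from compound 3 to compound 4 (within the scatter), so on this core too the change leaves the read-out essentially unchanged. Set beside the same change on the core of compound 1, the two steps cannot be told apart, and the change carries from one core to the other without a detectable difference: the same change on two cores in this assay, a number 1.5 percentage points lower (within the scatter) from compound 1 to compound 2 and a number 2.2 percentage points lower (within the scatter) from compound 3 to compound 4, 0.7 percentage points apart, within the scatter of two such steps. This shows agreement between two small steps on two cores, at a single oral dose; it does not show that the change would behave alike on any other core, and since neither step stands out from the scatter, it gives no sign of a real effect of the change that could be said to carry over, nor any reason why the two steps agree.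

The four compounds shown hold only bromo or methoxy on the aromatic ring and keep the ethyl ester throughout, so it stays open whether a different group there, such as an amine or a nitrile, would move the read-out beyond the scatter. On these data alone, it also stays open whether a carboxylic acid in place of the ethyl ester, or a longer chain at that end, would change the read-out on either core.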